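A Hydroxy Group in Place of Methyl on Compound 3

The compounds below may be only part of what the source reports. "The series", "measured", "known", "first", "only" and "open" are said of these compounds alone.

In a functional assay on A549 cells (Homo sapiens) for inhibition, read by MTT assay, with a stated time of 72 h (a higher number here means a weaker inhibitor, a lower number a stronger inhibitor), compound 1 `Cc1ccc(-c2nnc(SCCCN3CCN(c4nc5ccccc5o4)CC3)o2)cc1` gives 106000 nM and compound 2 `CC(C)(C)Oc1ccc(-c2nnc(SCCCN3CCN(c4nc5ccccc5o4)CC3)o2)cc1` gives 263000 nM. Compound 3 `Cc1ccc(-c2nnc(SCCCN3CCN(c4nc5ccccc5s4)CC3)o2)cc1` gives 53900 nM, the lowest number of the three, although it is not separated from compound 1: the series shows a 2.0-fold lower number from compound 1 to compound 3 (0.29 log units; within the scatter). Only compound 2 stands clearly apart from compound 3, with a markedly higher number.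

Compound 4 `Oc1ccc(-c2nnc(SCCCN3CCN(c4nc5ccccc5s4)CC3)o2)cc1` carries hydroxy in place of methyl on an aromatic carbon, the change from 4-methylphenyl to 4-hydroxyphenyl: hydroxy in place of methyl on an aromatic carbon. Going by the values given here, only one measured step touches this place, namely a 2.5-fold higher number from compound 1 to compound 2 (0.39 log units; beyond the scatter), where tert-butoxy takes the place of methyl. Among the compounds with values here, that step is modest, and it is only a loose guide, since no compound with hydroxy has been measured. The step to compound 3 concerns the group on the ring nitrogen and says nothing about this change. A small upward drift is therefore expected at most, probably not beyond the scatter. The expected step is a 1.3-fold higher number from compound 3 to compound 4 (0.11 log units; within the scatter). For compound 4 the estimated value is 70000 nM, with an expected range from 28000 nM to 170000 nM.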

Compound 4, half-maximal inhibitory concentration: 62100 nM
Compound 4: the middle estimate sits 1.1-fold (0.05 log units) above what was measured; low and high end bracket the measured number.
By their numbers in this assay, from the lowest: compounds 3, 4 and 1 (each within the scatter of the next); then compound 2.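

In this assay, hydroxy in place of methyl on the aromatic carbon gives a 1.2-fold higher number from compound 3 to compound 4 (0.06 log units; within the scatter), so compound 3 and compound 4 cannot be told apart, even though the entering group brings a hydrogen-bond donor and a hydrogen-bond acceptor that the methyl lacks. Going by these compounds alone, until now, the only change read at this place was tert-butoxy in place of methyl, with a 2.5-fold higher number from compound 1 to compound 2 (0.39 log units; beyond the scatter), and that step lies beyond the scatter; the new step shows that not every replacement of the methyl gives a readable difference, although the two steps stand on different partners, 1,3-benzoxazol-2-yl and 1,3-benzothiazol-2-yl. The data shown offer no independent evidence that would help interpret this result.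

The compounds shown leave open whether a methoxy group, an amine or a carboxylic acid at this same place would also stay within the scatter of compound 3. They also leave open whether hydroxy would behave in the same way alongside 1,3-benzoxazol-2-yl, and so whether the size of the entering group or the partner on the amine nitrogen governs the result.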